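The source may report more compounds than this note shows. Statements on the series, on what has been measured and on what is new or still open speak of the compounds shown alone.

Measured compounds:
compound 1 `Cc1nc(-c2ccc(Cl)cc2)sc1C(=O)CSc1nc(-c2ccc(Cl)c(Cl)c2)c(C#N)c(=O)[nH]1` — 46900 nM
compound 2 `COc1ccc(-c2nc(C)c(C(=O)CSc3nc(-c4ccc(OC)cc4)c(C#N)c(=O)[nH]3)s2)cc1` — "not determined" (no result reported)
compound 3 `COc1ccc(-c2nc(SCC(=O)c3sc(-c4ccc(Cl)cc4)nc3C)[nH]c(=O)c2C#N)cc1` — "not determined" (no result reported)

In an ADME assay on HEK293 cells (Homo sapiens) for cytotoxicity, read by MTT assay, with a stated time of 48 h (a lower number here means a stronger inhibitor, a higher number a weaker inhibitor), compound 1 gives 46900 nM. For compound 2 the entry in this assay reads "not determined" (no result reported). In this assay compound 3 likewise reads "not determined" (no result reported). Compound 3 therefore stands without a single number, and one further entry, compound 2, is also without one; only compound 1 carries a value in the set. Among the compounds with values here, no pair of measured compounds differs in one place, so no step size is known from measurement.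

Compound 4 `Cc1nc(-c2ccc(Cl)cc2)sc1C(=O)CSc1nc(-c2ccc(Cl)cc2)c(C#N)c(=O)[nH]1` is next to be measured in this assay. Against compound 3 the change is chloro in place of methoxy on an aromatic carbon. With compound 3 lacking a number, the step from compound 3 to compound 4 cannot be anchored at its start, and no direction can be read from the data; nothing beyond the scatter is expected in this assay for this change. Within the data shown here, the only numerical anchor is compound 1, whose value 46900 nM sits in the same weakly cytotoxic region and shares most of the structure of compound 4. Compound 4 is therefore expected near 45000 nM, within a range of 15000 nM to 110000 nM.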

Compound 4, half-maximal inhibitory concentration: 75100 nM
The estimate for compound 4 lay 1.7-fold (0.22 log units) below the measured number; measured number inside the range.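

In this assay the series now has its first measured step: hydrogen in place of chloro on an aromatic carbon gives a 1.6-fold higher number from compound 1 to compound 4 (0.20 log units; within the scatter), so the two compounds cannot be told apart in this read-out, and that one chloro shows no effect beyond repeat scatter. The step from 4-methoxyphenyl to 4-chlorophenyl, the change that links compound 3 to compound 4, cannot be read, since compound 3 has no number. No measured information on these compounds bears on the result, and the reading of this step stays purely descriptive.

Going by these compounds, whether methoxy at this place on the ring reads any differently from chloro or hydrogen stays open, as neither compound 2 nor compound 3 carries a value, and two values on closely related structures cannot show how far the result would hold across the series. Also open, on these data alone, is how a group of another kind at this place, such as an amine or a carboxylic acid, would read in this assay.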